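Clearance notes: from compound 2 to compound 3

The source may report more compounds than this note shows. Statements on the series, on what has been measured and on what is new or still open speak of the compounds shown alone.

Of the compounds shown here, two carry numbers so far. Compound 1 (`CC(C)NC(=O)[C@H]1CC[C@@H](n2/c(=N/C(=O)c3ccc(F)cc3)[nH]c3ccc(CN4CCC[C@H]4C(C)(C)O)cc32)CC1`) gives 569 mL.min-1.g-1 in an in vitro ADME assay on microsomes from liver (Homo sapiens) for metabolic stability (on this read-out higher numbers stand for fast clearance and lower numbers for slow clearance), as its measured value. Compound 2 (`CC(C)NC(=O)[C@H]1CC[C@@H](n2/c(=N/C(=O)c3cccc(C#N)c3)[nH]c3ccc(CN4CCC(C(C)(C)O)CC4)cc32)CC1`) gives 72 mL.min-1.g-1 in the same read-out, which is the lower of the two numbers, and the gap to compound 1 lies beyond the scatter. These two compounds differ in more than one place, so the gap cannot be tied to any single change.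

Compound 3 (`CC(C)NC(=O)[C@H]1CC[C@@H](n2/c(=N/C(=O)c3cccnc3)[nH]c3ccc(CN4CCC(C(C)(C)O)CC4)cc32)CC1`) has not yet been measured. It has pyridin-3-yl in place of 3-cyanophenyl on a carbonyl carbon, and the rest of compound 2 is kept. Going by the values given here, no measured pair shows this change, so the expectation starts from compound 2 at 72 mL.min-1.g-1 and nothing firmer. In this assay a small move towards slower clearance is expected, with no step beyond the scatter. The estimated change is a 1.3-fold lower number from compound 2 to compound 3 (0.12 log units; within the scatter) and it remains tentative. The expected value for compound 3 is 55 mL.min-1.g-1 with an estimated range from 22 mL.min-1.g-1 to 140 mL.min-1.g-1 for the coming measurement.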

Compound 3, intrinsic clearance in microsomes: 47 mL.min-1.g-1
The estimate for compound 3 lay 1.2-fold (0.07 log units) above the measured number; low and high end bracket the measured number.
By their numbers in this assay, from the lowest: compounds 3 and 2 (each within the scatter of the next); then compound 1.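

In this assay, going by these compounds alone, pyridin-3-yl in place of 3-cyanophenyl on a carbonyl carbon gives a 1.5-fold lower number from compound 2 to compound 3 (0.19 log units; within the scatter), the first reading of a change made in one place only. At this position, on the carbonyl carbon whose other neighbour is the amide-type nitrogen, the aromatic ring of carbon only with its nitrile and the aromatic ring with one hetero atom cannot be told apart on this read-out, so the shared remainder of the molecule keeps its clearance number when this group is exchanged. Nothing on hand bears on why the two groups read alike.

Within the data shown here, with both the nitrile and the ring nitrogen exchanged in one step, the single pair cannot show how each contributes alone, and a plain phenyl or a phenyl carrying a carboxylic acid at the same carbonyl carbon would test how far this insensitivity extends. On these data alone, compound 1 differs from compound 2 and compound 3 in more than one place, so the origin of its number remains open.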